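Replacing phenyl with ethoxycarbonyl in compound 2

The source may hold more compounds than are shown below. What is called first, only, known or untested is meant among the compounds shown, and "the series" means these compounds.

Of the compounds shown here, two have been tested so far in a functional assay on B16 cells (Mus musculus) for cytotoxicity, read by MTT assay, with a stated time of 48 h; a lower number here means a stronger inhibitor, a higher number a weaker inhibitor. Going by the values given here, compound 2 `O=C(NCc1cn(Cc2ccccc2)nn1)c1cn(Cc2ccccc2)nn1` gives 300 nM, the only actual number in the set. Compound 1 `C#CCNC(=O)c1cn(CC(=O)OCc2ccccc2)nn1` returns only a limit, > 100000 nM. Compound 3 `CCOC(=O)Cn1cc(CNC(=O)c2cn(Cc3ccccc3)nn2)nn1`, not yet measured, differs from compound 2 at one place: ethoxycarbonyl in place of phenyl on a saturated chain carbon bound to an aromatic nitrogen. Ethoxycarbonyl takes the place of phenyl on a saturated chain carbon bound to an aromatic nitrogen, so one benzyl becomes (ethoxycarbonyl)methyl. Among the compounds with values here, no measured pair shows what such a change does, which leaves the forecast loose. It rests on compound 2 at 300 nM, a value that leaves more room for loss than for gain. A weakening beyond the usual scatter is expected, with an estimated 10-fold higher number from compound 2 to compound 3 (1.00 log units; beyond the scatter). Compound 3 is estimated at 3000 nM, with an expected range of 400 nM to 30000 nM.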

Compound 3, half-maximal inhibitory concentration: 35000 nM
Estimate against measurement, compound 3: 12-fold (1.07 log units) below; the measured number lies above the stated range.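

In this assay, this position, a saturated chain carbon bound to an aromatic nitrogen, proves sensitive to what it carries: ethoxycarbonyl in place of phenyl gives a 120-fold higher number from compound 2 to compound 3 (2.07 log units; beyond the scatter). Turning one benzyl of compound 2 into (ethoxycarbonyl)methyl, which removes an aromatic ring and brings in two hydrogen-bond acceptors, costs most of the activity, even though the second benzyl stays in place. Compound 3 still returns a real number rather than a limit, so the full size of this step can be read: the limit of > 100000 nM in this assay, at which 1 of the 3 values shown sits.

The step removes the ring and brings in the ester at once, so the compounds shown leave open which of the two matters. They also leave open how a cyclohexyl or a carboxylic acid would read on this carbon, and whether the second benzyl responds to the same change.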